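Small steps around compound 3 in a cytotoxicity series

The source may hold more compounds than are shown below. What is called first, only, known or untested is meant among the compounds shown, and "the series" means these compounds.

Values measured in a functional assay on MCF7 cells (Homo sapiens) for cytotoxicity, read by MTT assay, with a stated time of 24 h (on this read-out lower numbers stand for stronger inhibition and higher numbers for weaker inhibition), are these.
compound 1 `CCNc1cc(-c2ccc(NC(=O)Nc3ccc(OC)cc3)cc2OC)ccn1` gives 17500 nM
compound 2 `CCNc1cc(-c2ccc(NC(=O)Nc3ccc(C(F)(F)F)cc3)cc2OC)ccn1` gives 19500 nM
compound 3 `CCNc1cc(-c2ccc(NC(=O)Nc3c(C)cccc3C)cc2OC)ccn1` gives 9260 nM
Still unmeasured is compound 4 `CCNc1cc(-c2ccc(NC(=O)Nc3ccccc3Cl)cc2OC)ccn1`

The three measured values lie close together. Compound 3 stands within the scatter of compound 1, with a 1.9-fold lower number from compound 1 to compound 3 (0.28 log units; within the scatter), and only modestly apart from compound 2, with a 2.1-fold lower number from compound 2 to compound 3 (0.32 log units; beyond the scatter). Compounds 1 and 2 cannot be told apart, with a 1.1-fold higher number from compound 1 to compound 2 (0.05 log units; within the scatter).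

The next step changes one group, and its count reads (2-chlorophenyl in place of 2,6-dimethylphenyl on an amide-type nitrogen). In words, it puts 2-chlorophenyl in place of 2,6-dimethylphenyl on an amide-type nitrogen.

The two steps ending at compound 3 bear most directly on this, since each exchanges the group on that same nitrogen. Both are small, one inside the scatter and one just past it. For the measured compounds named here, no measured compound carries 2-chlorophenyl, so the direction is poorly fixed. A slight rise is the better guess, as compound 1 and compound 2 both show higher numbers than compound 3, but no step beyond the scatter is expected in this assay. The expected step is a 1.3-fold higher number from compound 3 to compound 4 (0.11 log units; within the scatter). Compound 4 is estimated at 12000 nM, with an expected range from 6000 nM to 23000 nM.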

Compound 4, half-maximal inhibitory concentration: 9940 nM
The estimate for compound 4 lay 1.2-fold (0.08 log units) above the measured number; the measured number falls inside the stated range.
By their numbers in this assay, from the lowest: compounds 3, 4, 1 and 2 (each within the scatter of the next, the first and the last beyond it).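

In this assay, the exchange of 2,6-dimethylphenyl for 2-chlorophenyl on this amide-type nitrogen gives a 1.1-fold higher number from compound 3 to compound 4 (0.03 log units; within the scatter), so a phenyl group carrying chlorine and no methyl cannot be told apart here from the one carrying two methyls. For the compounds shown here, the new group also stays within the scatter of the two other aryl groups at this place, with a 2.0-fold lower number from compound 2 to compound 4 (0.29 log units; within the scatter) and a 1.8-fold lower number from compound 1 to compound 4 (0.25 log units; within the scatter); thus compound 4, unlike compound 3, has no step beyond the scatter to any other compound, and the one such step remains that between compound 2 and compound 3. No measurement is at hand that could account for how little these values respond to the exchange.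

The compounds shown leave open whether any group on this nitrogen can move the number clearly outside this narrow band, for example a phenyl group bearing a carboxylic acid or an amine, or a longer alkyl chain in place of the aryl group. They also leave open whether changes to the shared core would matter more than changes at this nitrogen.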